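Fluoro for hydrogen on the phenyl of compound 2

The source may report more compounds than this note shows. Statements on the series, on what has been measured and on what is new or still open speak of the compounds shown alone.

The three measured compounds, with their values in a physicochemical assay for lipophilicity, at pH 7.4; on this read-out higher numbers stand for higher lipophilicity and lower numbers for lower lipophilicity:

Compound 1, `CNC(=O)c1cc(C(=O)Nc2cnn(C)c2)cc2c1OC[C@H]2c1ccccc1`, gives 3.5.
Compound 2, `CNC(=O)c1cc(C(=O)NC2CC2)cc2c1OC[C@H]2c1ccccc1`, gives 3.6.
Compound 3, `CNC(=O)c1cc(C(=O)N[C@H]2[C@@H]3C[C@@H](O)C[C@@H]32)cc2c1OC[C@H]2c1ccccc1`, gives 2.9.

Compound 2 stands at the top of these three numbers in this assay, but its distance from compound 1 is only a number 0.10 log units higher from compound 1 to compound 2 (within the scatter), so the two cannot be told apart. Compound 3 lies clearly lower: the step is a number 0.70 log units lower from compound 2 to compound 3 (beyond the scatter), and from compound 1 the step is a number 0.60 log units lower from compound 1 to compound 3 (beyond the scatter).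

Compound 4, `CNC(=O)c1cc(C(=O)NC2CC2)cc2c1OC[C@H]2c1ccc(F)cc1`, differs from compound 2 in one place: fluoro in place of hydrogen on an aromatic carbon.

All three measured steps concern the group on the amide-type nitrogen; none of them changes the phenyl ring that carries the new fluoro. Among the compounds with values here, there is therefore no measured step that bears directly on this change. Without such a comparison, the expectation for the step in this assay is that it stays small, and the estimated step is a number 0.10 log units higher from compound 2 to compound 4 (within the scatter), not beyond the scatter.

Compound 4 is thus expected to give about 3.7 in this assay, estimated to fall between 3.3 and 4.1.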

Compound 4, distribution coefficient: 3.8
Compound 4: middle estimate off by 0.10 log units, on the low side, and the stated range covers the measured number.
By their numbers in this assay, from the lowest: compound 3; then compounds 1, 2 and 4 (each within the scatter of the next).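

In this assay, the swap of phenyl to 4-fluorophenyl on compound 2 gives a number 0.20 log units higher from compound 2 to compound 4 (within the scatter), so compound 2 and compound 4 cannot be told apart on this read-out. Within the data shown here, this is the first measured change on this phenyl ring, since every earlier step concerned the group on the amide-type nitrogen, and it shows that one fluoro on an aromatic carbon, para to a large group, leaves the number within the usual spread of repeat measurements, whereas the group on that nitrogen has already produced steps beyond it. Nothing measured here gives a reason for the size of this step.

Fluoro is the only group seen at this place, so it remains open whether a larger or charged group there, such as trifluoromethyl, an amine or a carboxylic acid, would move the number beyond the scatter. From the compounds shown here alone, it also remains open whether the same swap would read alike on the phenyl of compound 1 or compound 3, where a different group sits on the amide-type nitrogen.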